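The compounds below may be only part of what the source reports. "The series", "measured", "known", "first", "only" and "open" are said of these compounds alone.

Measured so far in an ADME assay on microsomes (Rattus norvegicus) for metabolic stability; a lower number here means that the compound disappears faster, a higher number that the compound lasts longer:
- compound 1 `CC(C)(C)C(=O)N1N=CCC1c1ccccn1`: 1.32 h
- compound 2 `O=C(C1CCN(C(=O)C(F)(F)F)CC1)N1N=CCC1c1ccccc1`: 0.483 h

Of these two numbers, compound 2 has the lower one at 0.483 h, and the gap to compound 1, which gives 1.32 h, lies beyond the scatter. Among the compounds with values here, the two compounds do not form a single-place pair, so no measured step is available as a guide.

Next is compound 3 `O=C(c1cc[nH]n1)N1CCC(C(=O)N2N=CCC2c2ccccc2)CC1`, which differs from compound 2 by 1H-pyrazol-3-yl in place of trifluoromethyl on a carbonyl carbon. In this assay, no step beyond the scatter is expected, with at most a slight rise. Within the data shown here, the estimate is anchored on compound 2 at 0.483 h, and the range stays wide since no measured step supports it. The expected change is a 1.2-fold higher number from compound 2 to compound 3 (0.09 log units; within the scatter). For compound 3 the estimated value is 0.6 h, with an expected range from 0.22 h to 1.6 h.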

Compound 3, half-life: 0.317 h
Compound 3: the middle estimate sits 1.9-fold (0.28 log units) above what was measured; low and high end bracket the measured number.
By their numbers in this assay, from the lowest: compounds 3 and 2 (each within the scatter of the next); then compound 1.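

In this assay, within the data shown here, the exchange of trifluoromethyl for 1H-pyrazol-3-yl on a carbonyl carbon gives a 1.5-fold lower number from compound 2 to compound 3 (0.18 log units; within the scatter) and is the first measured single-place step. At this position, on the carbonyl carbon whose other neighbour is the amide-type nitrogen in a ring, the read-out does not separate the two groups, even though the entering group brings a five-membered aromatic ring, a hydrogen-bond donor and a hydrogen-bond acceptor. No measured evidence bearing on this result is available.

On these data alone, whether a different group on this carbonyl carbon, such as a simple methyl, an amine or a carboxylic acid, would give a step beyond the scatter remains open. The gap between compound 1 and the other two compounds cannot be assigned to any single place.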